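The source may hold more compounds than are shown below. What is called first, only, known or untested is meant among the compounds shown, and "the series" means these compounds.

Of the compounds shown here, three built on one shared core have been measured in an assay on membranes from lung (Cavia porcellus) for binding affinity to cysteinyl leukotriene receptor (Homo sapiens); on this read-out lower numbers stand for stronger inhibition and higher numbers for weaker inhibition. Compound 1 `O=C(O)CCC(Cc1ccc(OCc2ccc3ccccc3n2)cc1)c1ccccc1` gives 31 nM, compound 3 `O=C(O)CCC(Cc1cccc(OCc2ccc3ccccc3n2)c1)c1ccccc1` gives 52 nM, and compound 2 `O=C(O)CCCCc1cccc(OCc2ccc3ccccc3n2)c1` gives 100 nM, the highest number of the three, though compound 3 sits within the scatter of it and only compound 1 lies beyond. Among the measured compounds shown here, the single step traced so far, a 1.9-fold lower number from compound 2 to compound 3 (0.28 log units; within the scatter), alters a different part of the chain. Compound 4 `c1cc(CCCCc2nnn[nH]2)cc(OCc2ccc3ccccc3n2)c1` differs from compound 2 in one place: 1H-tetrazol-5-yl in place of carboxy on a saturated chain carbon, four bonds along the chain from an aromatic carbon. For the measured compounds named here, no measured step changes the carboxy group, and the data give no direction for this change. A step no larger than the scatter is expected, no change at the digits printed from compound 2 to compound 4 (within the scatter). Compound 4 is therefore estimated at 100 nM, between 30 nM and 320 nM.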

Compound 4, inhibition constant: 20 nM
The estimate for compound 4 lay 5.0-fold (0.70 log units) above the measured number; measured number below the stated range.
By their numbers in this assay, from the lowest: compounds 4, 1, 3 and 2 (each within the scatter of the next, the first and the last beyond it).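

In this assay the move from carboxy to 1H-tetrazol-5-yl gives a 5.0-fold lower number from compound 2 to compound 4 (0.70 log units; beyond the scatter) and so is the first single change shown here that goes beyond the scatter. The end of this chain therefore responds to what sits on it, and carboxy is not needed there for binding. No measurement given here explains the lower number. From the compounds shown here alone, whether 1H-tetrazol-5-yl would also lower the number on the phenyl-bearing chain of compound 3 remains open. So does the effect of a sulfonamide or a hydroxamic acid in the same place.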